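Oxadiazole sulfones: a fluorine added to the chlorophenyl

This account rests on a few compounds, and the source may have more. Where it says the series, first, only, none or still open, it means among the compounds named here.

Compound 1, `CC(O)(CS(=O)(=O)c1ccccc1)c1nc(-c2ccccc2)no1`: in a functional assay on DU-145 cells (Homo sapiens) for cytotoxicity, read by MTT assay (on this read-out higher numbers stand for weaker inhibition and lower numbers for stronger inhibition), compound 1 gives only a limit, > 100000 nM.
Compound 2, `CC(O)(CS(=O)(=O)c1ccc(F)cc1)c1nc(-c2ccc(F)c(Cl)c2)no1`: in this assay compound 2 gives only a limit, > 100000 nM.
Compound 3, `CC(O)(CS(=O)(=O)c1ccccc1)c1nc(-c2ccc(Cl)cc2)no1`: in this assay compound 3 gives only a limit, > 100000 nM.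

Among the measured compounds shown here, compound 3 thus stands at the limit of > 100000 nM in this assay, at which 3 of the 3 values shown sit, and the one single-point step, a step that the two limits leave unreadable from compound 1 to compound 3, gives no readable size. Compound 4, `CC(O)(CS(=O)(=O)c1ccccc1)c1nc(-c2ccc(F)c(Cl)c2)no1`, differs from compound 3 by 3-chloro-4-fluorophenyl in place of 4-chlorophenyl on an aromatic carbon. Compound 2 already carries the same 3-chloro-4-fluorophenyl and sits at a limit as well, so no step beyond the scatter can be read from the data. Compound 4 is therefore expected to show a number no higher from compound 3 to compound 4 (the limit leaves the size open), most likely again only a limit; the estimate for compound 4 in this assay is 100000 nM, between 40000 nM and 300000 nM.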

Compound 4, half-maximal inhibitory concentration: > 100000 nM
Compound 4: no number, only a limit; the forecaster's own chance of this, stated with the estimate: 85%; the middle value lies on the limit itself.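

Compound 4, like compound 1, compound 2 and compound 3, gives only a limit, so none of the steps among them can be read: the limit of > 100000 nM in this assay, at which 4 of the 4 values shown sit.

The compounds shown leave open what change to the shared core, if any, would give a readable number in this assay.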